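The compounds below may be only part of what the source reports. "The series", "measured", "known", "first", "only" and "open" are said of these compounds alone.

Measured so far:
- Compound 1, `CC(C)=CCn1ccc2cc(/C(C)=C/C(=O)Nc3ccccc3OCCCC(=O)O)ccc21`: 120 nM
- Compound 2, `COc1ccc(Cn2ccc3cc(/C(C)=C/C(=O)Nc4ccccc4OCCCC(=O)O)ccc32)cc1`: 480 nM

In an assay on Prostate gland for inhibition of steroid 5-alpha-reductase (Rattus norvegicus) (on this read-out higher numbers stand for weaker inhibition and lower numbers for stronger inhibition), compound 1 has the lowest number of the two, so it is the stronger inhibitor. Compound 2 differs from it only at the group carried on the aromatic nitrogen, and that single swap gave a 4.0-fold higher number from compound 1 to compound 2 (0.60 log units; beyond the scatter). Compound 3, `CCC(c1ccccc1)n1ccc2cc(/C(C)=C/C(=O)Nc3ccccc3OCCCC(=O)O)ccc21`, is the next case: 1-phenylpropyl in place of 3-methylbut-2-en-1-yl on an aromatic nitrogen. For the measured compounds named here, this is the one measured step that bears on it, and it went in the weakening direction when the branched alkenyl group was exchanged for an aromatic ring. Compound 3 also brings in an aromatic ring, yet it keeps a saturated chain on the nitrogen, so the expectation is a weakening smaller than that seen for compound 2, about a 2.1-fold higher number from compound 1 to compound 3 (0.32 log units; beyond the scatter). For compound 3 the estimated value is 250 nM, with a range from 100 nM to 650 nM.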

Compound 3, half-maximal inhibitory concentration: 19 nM
Compound 3: the middle estimate sits 13-fold (1.12 log units) above what was measured; the measured number lies below the stated range.
By their numbers in this assay, from the lowest: compound 3; then compound 1; then compound 2.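

For the compounds shown here, the group on the aromatic nitrogen can strengthen inhibition as well as weaken it: in this assay, 1-phenylpropyl in place of 3-methylbut-2-en-1-yl gives a 6.3-fold lower number from compound 1 to compound 3 (0.80 log units; beyond the scatter), the opposite direction to the only earlier step. Bringing an aromatic ring onto this nitrogen therefore does not in itself cost inhibition, since compound 2 and compound 3 both carry one, yet 1-phenylpropyl in place of 4-methoxybenzyl gives a 25-fold lower number from compound 2 to compound 3 (1.40 log units; beyond the scatter), the largest step so far. No available measurement explains why these two ring-bearing groups differ so widely.

Still open, going by these compounds, is which part of that change counts, the ethyl branch of 1-phenylpropyl or the loss of the methoxy group; a plain benzyl group, carrying neither, would separate the two. Also open, on these data alone, is how a pyridine ring in place of the phenyl ring would fare on this nitrogen.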